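Working notes: replacing 3-chloro-4-fluorophenyl in compound 3

The compounds below may be only part of what the source reports. "The series", "measured", "known", "first", "only" and "open" are said of these compounds alone.

Measured in a functional assay on MDA-MB-231 cells (Homo sapiens) for inhibition, read by MTT assay, with a stated time of 48 h; on this read-out higher numbers stand for weaker inhibition of growth and lower numbers for stronger inhibition of growth:
- compound 1 `N=C(N)NS(=O)(=O)c1ccc(Nc2ncnc3ccc(NC(=S)NCc4ccccc4)cc23)cc1`: > 30000 nM (a limit of the assay, not a number)
- compound 2 `Oc1ccc(NC(=S)Nc2ccc3ncnc(Nc4cccc(Br)c4)c3c2)cc1`: 17300 nM
- compound 3 `Fc1ccc(NC(=S)Nc2ccc3ncnc(Nc4cccc(Br)c4)c3c2)cc1Cl`: 300 nM

Of the two true numbers in this assay, compound 3 holds the lower at 300 nM, and compound 2 gives 17300 nM. The gap between these two lies well beyond the scatter. Compound 1 gives only a limit.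

The next analogue is compound 4 `S=C(Nc1ccc(Br)cc1)Nc1ccc2ncnc(Nc3cccc(Br)c3)c2c1`, with 4-bromophenyl in place of 3-chloro-4-fluorophenyl on an amide-type nitrogen.

Among the measured compounds shown here, the only measured step at this place is a 58-fold lower number from compound 2 to compound 3 (1.76 log units; beyond the scatter). It is large, but it starts from 4-hydroxyphenyl, which compound 4 does not carry, so a step of that size is not expected here. This single step gives only a rough guide, and a modest move towards weaker inhibition of growth is expected. The expected change is a 2.3-fold higher number from compound 3 to compound 4 (0.37 log units; beyond the scatter).

For compound 4, the estimated value is 700 nM, with an expected range from 200 nM to 3000 nM.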

Compound 4, concentration for 50% growth inhibition: > 30000 nM
Compound 4: a limit, no number (the forecaster's own chance of this, stated with the estimate: 5%); middle value at least 42-fold (1.63 log units) away from the limit.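

In this assay compound 4 gives > 30000 nM, which is a limit of the assay and not a number. Sensitivity at this amide-type nitrogen is therefore not confined to the hydroxy group of compound 2: 4-bromophenyl in place of 3-chloro-4-fluorophenyl gives an at least 100-fold higher number from compound 3 to compound 4 (2.00 log units; beyond the scatter), although neither group carries a hydrogen-bond donor or acceptor. Bromo in place of hydroxy on an aromatic carbon gives an at least 1.7-fold higher number from compound 2 to compound 4 (0.23 log units; that floor lies within the scatter), so the two groups cannot be ranked, and the full size of both new steps stays unknown at the ceiling: the limit of > 30000 nM in this assay, at which 2 of the 4 values shown sit.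

Still open, on these data alone, is whether a phenyl carrying only the chloro or only the fluoro of compound 3 would hold its number. Also open, as far as these compounds go, is how an amine or a carboxylic acid on that phenyl would read.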